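The source may report more compounds than this note shows. Statements on the series, on what has been measured and on what is new or still open speak of the compounds shown alone.

The three measured compounds share one core, first seen in compound 1 `CNC(=O)c1cc(Oc2ccc(NC(=O)c3cc4cccnc4n(-c4ccccc4)c3=O)cc2)ccn1`, which in a functional assay on NCI-H460 cells (Homo sapiens) for antiproliferative activity, read by MTT assay, with a stated time of 72 h (on this read-out higher numbers stand for weaker inhibition and lower numbers for stronger inhibition), gives 320 nM. Compound 2 `CNC(=O)c1cc(Oc2ccc(NC(=O)c3cc4cccnc4n(-c4ccc(F)cc4)c3=O)cc2)ccn1` carries fluoro in place of hydrogen on an aromatic carbon, and in this assay compound 2 gives 210 nM; the step of a 1.5-fold lower number from compound 1 to compound 2 (0.18 log units; within the scatter) stays within the scatter. Compound 3 `CCNC(=O)c1cc(Oc2ccc(NC(=O)c3cc4cccnc4n(-c4ccccc4)c3=O)cc2)ccn1` instead carries methyl in place of hydrogen on a saturated chain carbon bound to an amide-type nitrogen, and in this assay compound 3 gives 1120 nM, the highest of the three numbers; the step of a 3.5-fold higher number from compound 1 to compound 3 (0.54 log units; beyond the scatter) lies beyond the scatter, so compound 3 sits clearly apart from the other two. Compound 4 `CCNC(=O)c1cc(Oc2ccc(NC(=O)c3cc4cccnc4n(-c4ccc(F)cc4)c3=O)cc2)ccn1` differs from compound 3 by fluoro in place of hydrogen on an aromatic carbon, the same difference that separates compound 1 from compound 2. Among the measured compounds shown here, only that one measured step bears on it, a 1.5-fold lower number from compound 1 to compound 2 (0.18 log units; within the scatter), and it did not exceed the scatter, so for compound 4 the expected step in this assay is a 1.4-fold lower number from compound 3 to compound 4 (0.15 log units; within the scatter), that is, no change beyond the scatter. Compound 4 is therefore estimated at 800 nM, with a range from 380 nM to 1700 nM.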

Compound 4, half-maximal inhibitory concentration: 220 nM
Compound 4: middle estimate off by 3.6-fold (0.56 log units), on the high side; the measured number lies below the stated range.
By their numbers in this assay, from the lowest: compounds 2, 4 and 1 (each within the scatter of the next); then compound 3.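

On this position, the change from phenyl to 4-fluorophenyl does not have a fixed size in this assay; it depends on the rest of the molecule, and its clear effect appears only on the core of compound 3, where the result is a 5.1-fold lower number from compound 3 to compound 4 (0.71 log units; beyond the scatter), unlike the small step on the core of compound 1: the same change on two cores in this assay, a 1.5-fold lower number (0.18 log units; within the scatter) from compound 1 to compound 2 and a 5.1-fold lower number (0.71 log units; beyond the scatter) from compound 3 to compound 4, 3.3-fold (0.52 log units) apart, beyond the scatter of two such steps Seen from the other side, the added methyl on the saturated chain has no effect beyond the scatter once the fluoro is present, with a 1.0-fold higher number from compound 2 to compound 4 (0.02 log units; within the scatter), whereas it did have such an effect without the fluoro: the same change on two cores in this assay, a 3.5-fold higher number (0.54 log units; beyond the scatter) from compound 1 to compound 3 and a 1.0-fold higher number (0.02 log units; within the scatter) from compound 2 to compound 4, 3.3-fold (0.52 log units) apart, beyond the scatter of two such steps The two changes therefore do not simply add across these four compounds, and the high number belongs only to compound 3, which carries the added methyl without the fluoro.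

As far as these compounds go, it remains open whether chloro or methoxy at the same place would offset the added methyl as the fluoro does, and whether the same would hold for a longer chain such as propyl on the amide nitrogen. The four numbers give no reason why the effect of the fluoro changes with the chain.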